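Chloro for methyl in an anilinopyrimidine cytotoxicity series

This account rests on a few compounds, and the source may have more. Where it says the series, first, only, none or still open, it means among the compounds named here.

The study concerns anilinopyrimidines carrying a (3-methylbut-2-en-1-yl)oxy group, examined in a functional assay on MT2 cells (Homo sapiens) for cytotoxicity, read by MTT assay; a higher number here means that more compound is tolerated, a lower number that less compound is tolerated. Compound 1 `CC(C)=CCOc1cc(Nc2ncccn2)ccc1C` gives 78000 nM in this assay. Compound 2 `CC(C)=CCOc1cc(Nc2ncccn2)ccc1Cl`, which differs by chloro in place of methyl on an aromatic carbon, gives 2500 nM; the step of a 31-fold lower number from compound 1 to compound 2 (1.49 log units; beyond the scatter) is a large one. Compound 3 `CC(C)=CCOc1cc(Nc2nc(C)cc(N)n2)ccc1Cl` has a different core; how its core differs from that of compound 1 is not broken down here. Compound 3 reaches only the limit of this assay, < 4 nM, so for compound 3 a limit rather than a number is known. Compound 4 `CC(C)=CCOc1cc(Nc2nc(N)cc(Cl)n2)ccc1Cl` has not yet been measured; it differs from compound 3 by chloro in place of methyl on an aromatic carbon. This is the same kind of change as that from compound 1 to compound 2, though its surroundings differ: there the methyl sat on a six-membered aromatic ring of carbon only, ortho to the (3-methylbut-2-en-1-yl)oxy group, here it sits on a six-membered aromatic ring with two nitrogens, meta to an amino group. For compound 4 an expected step that the limit leaves unreadable from compound 3 to compound 4 is estimated, resting on the earlier step of a 31-fold lower number from compound 1 to compound 2 (1.49 log units; beyond the scatter) and on compound 3 already sitting at the limit of < 4 nM in this assay, at which 1 of the 3 values shown sits. Compound 4 is therefore expected to give about 2 nM in this assay, most likely again only as a limit, within 0.4 nM to 10 nM.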

Compound 4, half-maximal cytotoxic concentration: 14 nM
Beside the measured number, compound 4's estimate is 7.0-fold (0.85 log units) below it, outside the stated range (above it).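

Chloro in place of methyl on an aromatic carbon gave an at least 3.5-fold higher number from compound 3 to compound 4 (0.54 log units; beyond the scatter) in this assay, so on this core the number rose, whereas on the core of compound 1 it had fallen, and the two steps do not agree: the same change on two cores in this assay, a 31-fold lower number (1.49 log units; beyond the scatter) from compound 1 to compound 2 and an at least 3.5-fold higher number (0.54 log units; beyond the scatter) from compound 3 to compound 4, at least 100-fold (2.03 log units) apart, beyond the scatter of two such steps. Compound 3 gives a limit and not a number: the limit of < 4 nM in this assay, at which 1 of the 4 values shown sits. The direction of the new step is therefore known but its full size is not, and with one pair on each core the result shows that this change did not carry over between these two cores, not how it would behave on any other core or which feature of the cores sets the difference.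

The compounds shown leave open what bromo or methoxy would give in place of the chloro on the core of compound 3. They also leave open how the amino group alone would shift the number on the core of compound 1.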